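Oxime ether at the aromatic carbon: compound 4

A few compounds are considered here, and "the series" means these few. Any claim that something is new, unique, unknown or untested is made for them only; others in the source may bear on it.

Compound 1 `Cc1nc(-c2ccccc2NCC2=NCCN2)cs1` carries a five-membered aromatic ring on the shared core, and in a functional assay for activation of Alpha-1B adrenergic receptor (Homo sapiens), read by calcium flux (a higher number here means that more compound is needed for the effect, a lower number that less compound is needed), compound 1 gives 69.2 nM. Compound 3 `CO/N=C/c1ccccc1NCC1=NCCN1` carries a group of 4 heavy atoms on that aromatic carbon instead. In this assay compound 3 gives < 5020 nM, which is a limit of the assay and not a number. Compound 2 `CC/C(=N\OC)c1ccccc1NCC1=NCCN1` carries a group of 6 heavy atoms on the same carbon. In this assay compound 2 gives < 100000 nM, again a limit and not a number. Compound 3 therefore stands only at a limit, and the limit of < 5020 nM in this assay, at which 1 of the 3 values shown sits, and the limit of < 100000 nM in this assay, at which 1 of the 3 values shown sits, mark the two limits among the three values shown.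

Compound 4 `CC/C(=N/OC)c1ccccc1NCC1=NCCN1` differs from compound 3 by a group of 6 heavy atoms (4 carbon, 1 nitrogen, 1 oxygen; no ring) in place of a group of 4 heavy atoms (2 carbon, 1 nitrogen, 1 oxygen; no ring), on an aromatic carbon.

Among the measured compounds shown here, the steps that bear on this change are a step that the limit leaves unreadable from compound 1 to compound 3 and a step that the two limits leave unreadable from compound 2 to compound 3, and a step that the limit leaves unreadable from compound 1 to compound 2 is likewise unreadable. No readable size or direction is available from them, so no step beyond the scatter can be asserted in either direction.

In this assay compound 4 is expected near 5000 nM, with a range from 500 nM to 50000 nM. The estimated step is a step that the limit leaves unreadable from compound 3 to compound 4, with its direction left open.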

Compound 4, half-maximal effective concentration: < 5020 nM
Compound 4 gave a limit, no number; the forecaster's own chance of this, stated with the estimate: 50%; the middle value lies beyond the limit too.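

Compound 4 gives < 5020 nM in this assay, a limit of the assay and not a number, so none of its steps to compound 1, compound 2 or compound 3 can be read. The compounds shown leave open whether the drawn double-bond configuration changes the concentration needed for activation in this assay, a question resting on this pair: the fact that compounds 2 and 4 differ only in the configuration as drawn.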